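The source may report more compounds than this note shows. Statements on the series, on what has been measured and on what is new or still open speak of the compounds shown alone.

Working notes on the series. Compound 1 `O=c1cc(CSc2nc3ccccc3s2)oc2ccccc12` is the starting point. In a functional assay on MDA-MB-435S cells (Homo sapiens) for cytotoxicity, read by MTT assay, with a stated time of 72 h (a higher number here means a weaker inhibitor, a lower number a stronger inhibitor), compound 1 gives only a limit, > 25000 nM, not a number. Compound 2 `O=c1cc(CSc2nc3ccccc3o2)c2ccc(O)c(O)c2o1` is the second member recorded. In this assay compound 2 likewise gives only a limit, > 25000 nM. Compound 1 thus stands at the limit of > 25000 nM in this assay, at which 2 of the 2 values shown sit; no numerical value anywhere in the series places it above or below anything.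

Compound 3 `O=c1cc(CSc2nc3ccccc3s2)oc2ccc(Cl)cc12` has not been measured. Against compound 1 the change is chloro in place of hydrogen on an aromatic carbon. Among the compounds with values here, no measured step tells what such a change does, so no step beyond the scatter is expected in this assay in either direction. The estimate for compound 3 in this assay is 30000 nM, with a range from 10000 nM to 100000 nM, most likely reported again only as a limit. The expected step that the limit leaves unreadable from compound 1 to compound 3 is therefore essentially none.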

Compound 3, half-maximal inhibitory concentration: > 25000 nM
Compound 3: only a limit was reported; the forecaster's own chance of this, stated with the estimate: 75%; the middle value lies beyond the limit too.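

No step can be read between compound 1 and compound 3 in this assay, because both values are only limits: the limit of > 25000 nM in this assay, at which 3 of the 3 values shown sit. Going by these compounds, what chloro in place of hydrogen on an aromatic carbon does to the core of compound 1 in this assay stays open, as does any ordering among the three compounds.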